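A few compounds are considered here, and "the series" means these few. Any claim that something is new, unique, unknown or untested is made for them only; others in the source may bear on it.

Measured in an assay on LtK cells with ATP-sensitive inward rectifier potassium channel 11 (Homo sapiens) as the target; a lower number here means that less compound is needed, a higher number that more compound is needed for the effect:
compound 1, `CC(C)=CC(=O)Nc1c(C(O)(C(F)(F)F)C(F)(F)F)ccc2ccccc12`, 46 nM
compound 2, `C/C=C/C(=O)Nc1c(C(O)(C(F)(F)F)C(F)(F)F)ccc2ccccc12`, 72 nM
compound 3, `O=C(Nc1c(C(O)(C(F)(F)F)C(F)(F)F)ccc2ccccc12)C1CCC1`, 45 nM

Compound 3 gives the lowest number of the three, but a 1.0-fold lower number from compound 1 to compound 3 (0.01 log units; within the scatter) and a 1.6-fold lower number from compound 2 to compound 3 (0.20 log units; within the scatter) both lie within the scatter, so no order among the three can be stated. Compound 4, `O=C(NCCCCCCCl)Nc1c(C(O)(C(F)(F)F)C(F)(F)F)ccc2ccccc12`, is not yet measured; it differs from compound 3 by (6-chlorohexyl)amino in place of cyclobutyl on a carbonyl carbon. All measured steps exchange the group on the same carbonyl carbon: a 1.6-fold higher number from compound 1 to compound 2 (0.19 log units; within the scatter), a 1.0-fold lower number from compound 1 to compound 3 (0.01 log units; within the scatter), a 1.6-fold lower number from compound 2 to compound 3 (0.20 log units; within the scatter), each within the scatter. None of them brings an amino group onto that carbon, so the present change lies outside what the measured steps cover. The expected step is small, a 1.8-fold higher number from compound 3 to compound 4 (0.25 log units; within the scatter), not clearly beyond the scatter. Compound 4 is estimated at 80 nM in this assay, within 25 nM to 250 nM.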

Compound 4, half-maximal effective concentration: 4840 nM
Compound 4: the middle estimate sits 61-fold (1.78 log units) below what was measured; measured number above the stated range.
By their numbers in this assay, from the lowest: compounds 3, 1 and 2 (each within the scatter of the next); then compound 4.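

In this assay the carbonyl carbon is not indifferent to its substituent: the three groups seen earlier stay within the scatter of one another, but (6-chlorohexyl)amino gives a 110-fold higher number from compound 3 to compound 4 (2.03 log units; beyond the scatter), and likewise a 67-fold higher number from compound 2 to compound 4 (1.83 log units; beyond the scatter) and a 110-fold higher number from compound 1 to compound 4 (2.02 log units; beyond the scatter). Going by these compounds alone, this is the first step at this place beyond the scatter, and it holds against all three earlier groups. Nothing available bears on the cause of this rise.

Open, as far as these compounds go, is whether the amino link, the chain or the chlorine carries the step. Cyclobutylamino and plain hexylamino on the same carbonyl carbon would separate these.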